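Methyl on the aromatic ring of compound 1

The source may report more compounds than this note shows. Statements on the series, on what has been measured and on what is new or still open speak of the compounds shown alone.

Compounds measured so far:
compound 1, `COC(=O)[C@@]1(C)CC[C@@H]2C3=C1CC[C@@H](C)[C@]3(C)C[C@@H]1c3ccccc3N[C@H]21`: 39000 nM
compound 2, `COC(=O)[C@@]1(C)CC[C@@H]2C3=C1CC[C@@H](C)[C@]3(C)C[C@@H]1c3cc(Cl)ccc3N[C@H]21`: 35000 nM

In a functional assay on A549 cells (Homo sapiens) for inhibition, read by sulforhodamine B assay, with a stated time of 48 h (a lower number here means a stronger inhibitor of growth, a higher number a weaker inhibitor of growth), compound 1 gives 39000 nM. Among the compounds with values here, compound 2 sits beside it: the only measured step, a 1.1-fold lower number from compound 1 to compound 2 (0.05 log units; within the scatter), lies within the scatter, so the two numbers cannot be told apart. Compound 3, `COC(=O)[C@@]1(C)CC[C@@H]2C3=C1CC[C@@H](C)[C@]3(C)C[C@@H]1c3cccc(C)c3N[C@H]21`, differs from compound 1 by methyl in place of hydrogen on an aromatic carbon. Within the data shown here, the one step that bears on this change is the exchange of a hydrogen for a chloro on the same ring in compound 2, and that step, a 1.1-fold lower number from compound 1 to compound 2 (0.05 log units; within the scatter), was too small to count. On this evidence a small group on an aromatic carbon of that ring has left this assay unchanged, and the step of a 1.1-fold lower number from compound 1 to compound 3 (0.02 log units; within the scatter) is therefore expected to stay within the scatter as well. Compound 3 is accordingly estimated at 37000 nM, with a range from 18000 nM to 75000 nM.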

Compound 3, concentration for 50% growth inhibition: 30000 nM
Estimate against measurement, compound 3: 1.2-fold (0.09 log units) above, within the range that was stated.
By their numbers in this assay, from the lowest: compounds 3, 2 and 1 (each within the scatter of the next).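

In this assay, methyl on this aromatic carbon, ortho to a fused ring and meta to a fused ring, gives a 1.3-fold lower number from compound 1 to compound 3 (0.11 log units; within the scatter), so this single added carbon leaves the number indistinguishable from that of compound 1. This adds a direct reading for methyl, a group that compound 2 did not carry, and compounds 1, 2 and 3 now all lie within the scatter of one another. No measurement shown bears on the reason for this result.

Going by these compounds, whether the same aromatic carbon would stay within the scatter when carrying an amine, a carboxylic acid or a longer chain such as propyl remains open. The compounds shown also leave open whether any replacement of hydrogen on this ring can move the number beyond the scatter.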